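This account rests on a few compounds, and the source may have more. Where it says the series, first, only, none or still open, it means among the compounds named here.

Measured compounds:
Compound 1, `CC(C)C(=O)N1CC2CC(C1)N2`: in an assay on SH-EP1 cells for agonist activity at Neuronal acetylcholine receptor; alpha4/beta2 (Homo sapiens), read by FLIPR and calcium flux (a higher number here means a larger maximal response, a lower number a smaller maximal response), compound 1 gives 86%.
Compound 2, `O=C([C@@H]1C[C@H]1F)N1CC2CC(C1)N2`: in this assay compound 2 gives 110%.
Compound 3, `C[C@@H]1C[C@@H]1C(=O)N1CC2CC(C1)N2`: in this assay compound 3 gives 88%.

Among these three numbers compound 3 stands second highest. Its gap to compound 1, a number 2 percentage points higher from compound 1 to compound 3 (within the scatter), lies within the usual scatter, so no order between those two can be read. The step of a number 22 percentage points lower from compound 2 to compound 3 (beyond the scatter) is beyond the scatter, as is a number 24 percentage points higher from compound 1 to compound 2 (beyond the scatter), so compound 2 stands clearly above the other two.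

Compound 4, `C[C@H]1C[C@@H]1C(=O)N1CC2CC(C1)N2`, is the next compound. Compared with compound 3 the change is: the two compounds have the same atoms and bonds; at least one stereo element is drawn with a configuration in one of them and without one in the other: 1 of 4 stereo elements differ; a stereocentre at a saturated ring carbon is drawn R in compound 3 and S in compound 4. Atoms and bonds stay the same; only the drawn configuration at one ring carbon is flipped.

For the measured compounds named here, none of the measured steps involves such a flip: all of them swap the whole group on the carbonyl carbon. They therefore bear on this step only indirectly, by showing that swapping the group moves the number by a modest amount at most, and that the two cyclopropyl-bearing compounds differ from each other. Going by the values given here, with no direct precedent, the expected step of no change at the digits printed from compound 3 to compound 4 (within the scatter) is one that should stay within the scatter. The number expected for compound 4 in this assay is 88%, within a range of 68% to 112%.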

Compound 4, largest response reached (Emax), in percent of the reference or control that the assay uses: 67%
The estimate for compound 4 lay 21 percentage points above the measured number; the whole stated range lies above it.
By their numbers in this assay, from the lowest: compound 4; then compounds 1 and 3 (each within the scatter of the next); then compound 2.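

In this assay, the group on the carbonyl carbon is sensitive not only to which atoms it holds but also to how they are arranged in space. Flipping the drawn configuration at one saturated ring carbon, with atoms and bonds unchanged, gives a number 21 percentage points lower from compound 3 to compound 4 (beyond the scatter). The 2-methylcyclopropyl group can therefore no longer be treated as a single replacement for isopropyl: one form gave a number 2 percentage points higher from compound 1 to compound 3 (within the scatter), whereas the other gave a number 19 percentage points lower from compound 1 to compound 4 (beyond the scatter), and the gap to the 2-fluorocyclopropyl compound widens to a number 43 percentage points lower from compound 2 to compound 4 (beyond the scatter). The reading of the flip rests on one structural fact: the fact that one of compounds 3 and 4 is drawn with a defined configuration and the other without, at the place where they differ.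

From the compounds shown here alone, it remains open whether the same kind of flip in the 2-fluorocyclopropyl group of compound 2 would lower the number as well, or whether the fluorine would change the outcome. The compounds shown also leave unclear how a 2-ethylcyclopropyl or a cyclobutyl group on the same carbonyl carbon would behave.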